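Adding a phenyl to the benzoyl ring of compound 3

The compounds below may be only part of what the source reports. "The series", "measured", "known", "first", "only" and "open" are said of these compounds alone.

Of the compounds shown here, three sharing one core have been tested in a functional assay on A549 cells (Homo sapiens) for cytotoxicity, read by MTT assay, with a stated time of 48 h; a higher number here means a weaker inhibitor, a lower number a stronger inhibitor. Compound 1 `COc1cc(-c2nnc3n2NC(c2cccs2)C(C(=O)c2ccccc2)S3)cc(OC)c1OC` gives 69400 nM. Compound 2 `COc1cc(-c2nnc3n2NC(c2cccs2)C(C(=O)c2ccc(F)cc2)S3)cc(OC)c1OC` gives 45000 nM. Compound 3 `COc1cc(-c2nnc3n2NC(c2ccco2)C(C(=O)c2ccccc2)S3)cc(OC)c1OC` gives 33400 nM, the lowest of the three numbers, though its gap to compound 2 lies within the scatter and only its gap to compound 1 goes beyond it, as a 2.1-fold lower number from compound 1 to compound 3 (0.32 log units; beyond the scatter).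

Compound 4 `COc1cc(-c2nnc3n2NC(c2ccco2)C(C(=O)c2ccc(-c4ccccc4)cc2)S3)cc(OC)c1OC` differs from compound 3 in one place: phenyl in place of hydrogen on an aromatic carbon. Going by the values given here, the only measured step that touches the same aromatic ring is a 1.5-fold lower number from compound 1 to compound 2 (0.19 log units; within the scatter), a small change that stays within the scatter. Among the compounds with values here, no measured pair shows what a phenyl added at that position does, so the expectation rests on that single nearby step and on the absence of any large swing among the three numbers.

Compound 4 is therefore expected to give a number close to that of compound 3, with a step of a 1.1-fold lower number from compound 3 to compound 4 (0.05 log units; within the scatter) that need not pass the scatter. The estimate for compound 4 in this assay is 30000 nM, with a range from 10000 nM to 90000 nM.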

Compound 4, half-maximal inhibitory concentration: > 100000 nM
Compound 4 ended at the assay's limit (the forecaster's own chance of this, stated with the estimate: 10%); at least 3.3-fold (0.52 log units) between middle value and limit.
By their numbers in this assay, from the lowest: compounds 3, 2 and 1 (each within the scatter of the next, the first and the last beyond it). At a limit, above all of these: compound 4.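

In this assay compound 4 gives > 100000 nM, which is a limit of the assay and not a true number. Even so, the step can be read as an at least 2.9-fold higher number from compound 3 to compound 4 (0.47 log units; beyond the scatter), so this carbon of the benzoyl ring, para to a large group, does not accept every change equally. Going by these compounds alone, on the same ring, a fluoro gave only a 1.5-fold lower number from compound 1 to compound 2 (0.19 log units; within the scatter), whereas the added phenyl is the first change on this ring to go beyond the scatter.

As far as these compounds go, how far the true value of compound 4 lies past the limit remains unknown, so the full size of this loss is open. Also open, from the compounds shown here alone, is where between hydrogen and phenyl the number starts to climb, and whether a methoxy, an amine or a carboxylic acid on this carbon would keep it near that of compound 3.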